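This account rests on a few compounds, and the source may have more. Where it says the series, first, only, none or still open, it means among the compounds named here.

Measured so far in an assay on isolated protein for agonist activity at Bile acid receptor (Homo sapiens), read by AlphaScreen, with a stated time of 30 min; a lower number here means that less compound is needed, a higher number that more compound is needed for the effect:
compound 1 `Cc1ccccc1-n1nc(C)c2c1NC(=O)[C@H](C)S[C@@H]2c1ccc(-c2ccoc2)cc1` gives 3500 nM
compound 2 `COC(=O)c1cccc(-c2ccc([C@H]3S[C@@H](C)C(=O)Nc4c3c(C)nn4-c3ccccc3C)cc2)c1` gives "not active" (no number reported)
compound 3 `COc1ccc(Oc2ccc([C@H]3S[C@@H](C)C(=O)Nc4c3c(C)nn4-c3ccccc3C)cc2)cc1` gives 2200 nM

Compound 3 holds the lowest of the two numbers recorded in this assay; the nearest is compound 1, and the step of a 1.6-fold lower number from compound 1 to compound 3 (0.20 log units; within the scatter) lies within the scatter, so the two cannot be ordered. Compound 2, which carries a methoxycarbonyl group on its second aromatic ring, returned no number in this assay.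

Compound 4 `Cc1ccccc1-n1nc(C)c2c1NC(=O)[C@H](C)S[C@@H]2c1ccc(-c2ccc(C(=O)O)cc2)cc1` differs from compound 3 as follows: 4-carboxyphenyl in place of 4-methoxyphenoxy on an aromatic carbon. The 4-carboxyphenyl enters on the aromatic carbon para to a large group. Within the data shown here, only one measured step touches this place, a 1.6-fold lower number from compound 1 to compound 3 (0.20 log units; within the scatter), and it was within the scatter, so the one exchange made there so far moved the number little. Among the measured compounds shown here, compound 2, the only compound bearing a carbonyl group on an aryl at the outer end of the molecule, gave no number, and that weighs against compound 4. On this basis the number for compound 4 is expected to rise by a 3.2-fold higher number from compound 3 to compound 4 (0.50 log units; beyond the scatter), with a real chance that this assay again reports no number. The estimate for compound 4 in this assay is 7000 nM, within 2500 nM to 20000 nM.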

Compound 4, half-maximal effective concentration: "not active" (no number reported)
For compound 4 the study gives words and no number, and the estimate cannot be compared.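

In this assay, among these compounds, compound 4 gives "not active" (no number reported) and so no step from compound 3 to compound 4 can be read. No measured evidence bears on this result. The compounds shown leave open whether any compound with a carbonyl-bearing outer aryl group, as in compound 2 and compound 4, can give a number in this assay at all.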